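Does a Third Bromine Change the Picture for Compound 1

A few compounds are considered here, and "the series" means these few. Any claim that something is new, unique, unknown or untested is made for them only; others in the source may bear on it.

In a functional assay on A549 cells (Homo sapiens) for inhibition, read by MTT assay, with a stated time of 48 h (a higher number here means a weaker inhibitor, a lower number a stronger inhibitor), compound 1 `COc1cc(/C=N/Nc2nc(-c3ccccc3)cs2)c(Br)c(Br)c1OC` gives 15300 nM, the lowest number of the three compounds measured. Compound 3 `COc1cc(/C=N/Nc2nc(-c3ccccc3)cs2)cc(Br)c1OC` gives 40000 nM, and compound 2 `COc1cc(/C=N/Nc2nc(-c3ccc(Br)cc3)cs2)cc(Br)c1OC` gives 52300 nM. Compound 4 `COc1cc(/C=N/Nc2nc(-c3cccc(Br)c3)cs2)c(Br)c(Br)c1OC` differs from compound 1 in a single place: bromo in place of hydrogen on an aromatic carbon. The step that bears on this change runs in the opposite direction: a 1.3-fold lower number from compound 2 to compound 3 (0.12 log units; within the scatter), so taking a bromo off that ring made no difference beyond the scatter. The other step, a 2.6-fold higher number from compound 1 to compound 3 (0.42 log units; beyond the scatter), concerns a bromo on the other ring and says little here. The added bromo is therefore expected to bring only a small step, if any, a 1.1-fold higher number from compound 1 to compound 4 (0.05 log units; within the scatter). Compound 4 is estimated at 17000 nM, with a range from 7000 nM to 40000 nM.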

Compound 4, half-maximal inhibitory concentration: 37000 nM
Compound 4: middle estimate off by 2.2-fold (0.34 log units), on the low side, and the stated range covers the measured number.
By their numbers in this assay, from the lowest: compound 1; then compounds 4, 3 and 2 (each within the scatter of the next).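

On the core of compound 1, going from phenyl to 3-bromophenyl is not a neutral change: in this assay it gives a 2.4-fold higher number from compound 1 to compound 4 (0.38 log units; beyond the scatter) and so a weaker inhibitor. The earlier compounds shown here showed this change only as a step within the scatter. The two steps still do not truly disagree, and the size of the effect may be similar on both cores: the same change on two cores in this assay, a 1.3-fold lower number (0.12 log units; within the scatter) from compound 2 to compound 3 and a 2.4-fold lower number (0.38 log units; beyond the scatter) from compound 4 to compound 1, 1.8-fold (0.27 log units) apart, within the scatter of two such steps

Going by these compounds, what remains open is how other groups at this place on the phenyl ring, such as an amine or a carboxylic acid, would compare with hydrogen and bromo.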